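A few compounds are considered here, and "the series" means these few. Any claim that something is new, unique, unknown or untested is made for them only; others in the source may bear on it.

Compound 1 `O=C1/C(=C/c2ccc(F)cc2)Cc2ccccc21`: > 50000 nM (a limit of the assay)
Compound 2 `O=C1/C(=C/c2ccc(Cl)cc2)CCCc2ccccc21`: 9500 nM

Going by the values given here, only two compounds have been measured in a functional assay on P388 cells (Mus musculus) for inhibition (on this read-out higher numbers stand for weaker inhibition and lower numbers for stronger inhibition), and they differ in more than one place. Among the compounds with values here, compound 2 gives 9500 nM, the only actual number available. It therefore stands alone, with no second number to rank it against. Compound 1 is recorded at > 50000 nM, which is a limit and not a number.

Compound 3 `COc1ccc(/C=C2\CCCc3ccccc3C2=O)cc1` keeps the core of compound 2 and changes one substituent, with methoxy in place of chloro on an aromatic carbon, para to a large group: methoxy in place of chloro on an aromatic carbon.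

Within the data shown here, no measured pair shows what a change at this place does in this assay. Among the measured compounds shown here, the expectation therefore has no measured step behind it and stays cautious, with no step beyond the scatter and no firm direction. The estimated change is a 1.1-fold higher number from compound 2 to compound 3 (0.02 log units; within the scatter), and it is expected to remain small. Compound 3 is estimated at 10000 nM, with an expected range of 3000 nM to 35000 nM.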

Compound 3, half-maximal inhibitory concentration: 1600 nM
Compound 3: the middle estimate sits 6.3-fold (0.80 log units) above what was measured; the measured number lies below the stated range.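

In this assay, going by these compounds alone, methoxy in place of chloro on an aromatic carbon, para to a large group, gives the first measured change at this position: a 5.9-fold lower number from compound 2 to compound 3 (0.77 log units; beyond the scatter). Compound 1 and compound 2 differ in more than one place and gave no reading of this position, whereas this pair shows that exchanging a single substituent on an otherwise unchanged core is enough to move the number beyond the scatter, towards stronger inhibition. The data hold no measurement that would account for this step.

A single step cannot tell whether this direction holds for other groups at the same place, such as an amine or a carboxylic acid, or whether the size of the change is particular to chloro and methoxy. Nor does it show what a longer chain, such as ethoxy in place of methoxy, would do in this assay or whether the same exchange on the core of compound 1 would give a step of similar size.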